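Notes on a methoxyphenyl exchange, compound 3 to compound 4

A few compounds are considered here, and "the series" means these few. Any claim that something is new, unique, unknown or untested is made for them only; others in the source may bear on it.

Of the compounds shown here, three sharing one core have been read in a functional assay on DU-145 cells (Homo sapiens) for antiproliferative activity, read by MTT assay, with a stated time of 24 h; a lower number here means a stronger inhibitor, a higher number a weaker inhibitor. Compound 1 `COc1cc(-c2cc(C(=O)/C=C/c3ccc(C)cc3)nc3cc(-c4ccccc4)nn23)cc(OC)c1OC` gives 21900 nM. Compound 2 `COc1cc(C(=O)/C=C/c2cc(-c3cc(OC)c(OC)c(OC)c3)n3nc(-c4ccccc4)cc3n2)cc(OC)c1OC` gives 34900 nM. Compound 3 `COc1ccc(C(=O)/C=C/c2cc(-c3ccc(OC)cc3)n3nc(-c4ccccc4)cc3n2)cc1` gives 8500 nM, the lowest number of the three; the gap to compound 1 and the gap to compound 2 both lie beyond the scatter, so compound 3 is the strongest inhibitor of the three on these numbers. Among the compounds with values here, compound 4 `COc1ccc(C(=O)/C=C/c2cc(-c3cc(OC)c(OC)c(OC)c3)n3nc(-c4ccccc4)cc3n2)cc1` has not yet been read. It differs from compound 3 in one place: 3,4,5-trimethoxyphenyl in place of 4-methoxyphenyl on an aromatic carbon. Within the data shown here, no pair of measured compounds differs in exactly one place, so there is no measured step to lean on. Compound 2 carries the 3,4,5-trimethoxyphenyl at that aromatic carbon and gives the highest number of the three, while compound 3 carries 4-methoxyphenyl there and gives the lowest, but these two also differ elsewhere, so only their values can be set side by side. From compound 3 to compound 4 the number is expected to rise moderately, a 1.9-fold higher number from compound 3 to compound 4 (0.27 log units; within the scatter), beyond the scatter but short of the distance to compound 2. Compound 4 is accordingly estimated at 16000 nM, with a range from 6000 nM to 40000 nM.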

Compound 4, half-maximal inhibitory concentration: 25200 nM
The estimate for compound 4 lay 1.6-fold (0.20 log units) below the measured number; low and high end bracket the measured number.
By their numbers in this assay, from the lowest: compound 3; then compounds 1, 4 and 2 (each within the scatter of the next).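

In this assay, this aromatic carbon now has its first single-place step: a 3.0-fold higher number from compound 3 to compound 4 (0.47 log units; beyond the scatter) shows that 3,4,5-trimethoxyphenyl in place of 4-methoxyphenyl weakens inhibition beyond the scatter while the rest of the molecule stays the same. With 3,4,5-trimethoxyphenyl held at this carbon, the exchange on the carbonyl carbon gives a 1.4-fold lower number from compound 2 to compound 4 (0.14 log units; within the scatter) and the exchange of the side chain gives a 1.2-fold higher number from compound 1 to compound 4 (0.06 log units; within the scatter), both within the scatter, so neither change separates these compounds, and among the compounds shown only the 4-methoxyphenyl at this carbon, in compound 3, stands apart. The series holds no measurement that accounts for the step at this carbon.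

Going by these compounds, it remains open whether the step from 4-methoxyphenyl to 3,4,5-trimethoxyphenyl would have the same size with a different group on the carbonyl carbon or with the side chain of compound 1. Also open, on these data alone, is how this carbon responds to an unsubstituted phenyl, or to a phenyl carrying a hydroxyl, an amine or a carboxylic acid.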